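The source may hold more compounds than are shown below. What is called first, only, known or untested is meant among the compounds shown, and "the series" means these compounds.

Compound 3, `Cc1cc(S(N)(=O)=O)ccc1NC(=O)COc1ccc(F)cc1Oc1ccc2ccccc2c1Br`, is one of three compounds that have been tested in an ADME assay on C8166 cells (Homo sapiens) for cytotoxicity, read by MTT assay; a lower number here means that less compound is tolerated, a higher number that more compound is tolerated. In this assay compound 3 gives 39500 nM. Compound 1, `Cc1cc(S(N)(=O)=O)ccc1NC(=O)COc1ccc(Cl)cc1Oc1ccc2ccccc2c1Br`, gives 48100 nM, and compound 2, `Cc1cc(S(N)(=O)=O)ccc1NC(=O)COc1ccc(F)cc1Oc1ccc2ccccc2c1C`, gives 56100 nM. Compound 3 thus carries the lowest of the three numbers, yet neither neighbour is separated from it by more than the scatter: the step of a 1.2-fold lower number from compound 1 to compound 3 (0.09 log units; within the scatter) and the step of a 1.4-fold lower number from compound 2 to compound 3 (0.15 log units; within the scatter) both stay within it, so no order among the three can be read from these numbers.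

Compound 4, `Cc1cc(S(N)(=O)=O)ccc1NC(=O)COc1ccc(F)cc1Oc1ccc2cc(Br)ccc2c1Cl`, differs from compound 3 in one place: 6-bromo-1-chloronaphthalen-2-yl in place of 1-bromonaphthalen-2-yl on an oxygen on an aromatic ring. Among the measured compounds shown here, the closest precedent is the step from compound 2 to compound 3, which also altered a substituent on an aromatic carbon of the same naphthalenyl group and stayed within the scatter, as did the step from compound 1 to compound 3 on the other aromatic ring. For the measured compounds named here, neither step is the change made here, and no measured pair adds a second substituent to that group. On this basis no step beyond the scatter is expected for compound 4 in this assay, and the estimate is 40000 nM, with a range from 20000 nM to 80000 nM, which would mean a step of a 1.0-fold higher number from compound 3 to compound 4 (0.01 log units; within the scatter).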

Compound 4, half-maximal cytotoxic concentration: 195000 nM
Compound 4: middle estimate off by 4.9-fold (0.69 log units), on the low side, and the stated range ends below it.
By their numbers in this assay, from the lowest: compounds 3, 1 and 2 (each within the scatter of the next); then compound 4.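

In this assay, the group on the oxygen proves to be a place where the number can move beyond the scatter: there is a 4.9-fold higher number from compound 3 to compound 4 (0.69 log units; beyond the scatter) when 6-bromo-1-chloronaphthalen-2-yl replaces 1-bromonaphthalen-2-yl, and a 3.5-fold higher number from compound 2 to compound 4 (0.54 log units; beyond the scatter) when the same group replaces 1-methylnaphthalen-2-yl. The earlier steps shown here, one on this naphthalenyl group and one on the other aromatic ring, stayed within the scatter, so a single swap of one substituent there gave no hint of what this larger change does. Both steps beyond the scatter end at compound 4, which now stands apart from the other three compounds, and no available evidence accounts for the shift.

The change to compound 4 alters two things on the naphthalenyl group at once, and the compounds shown do not separate the contribution of the chloro from that of the added bromo. From the compounds shown here alone, it also remains open whether the number would move in the same way with an amine or a carboxylic acid on that group in place of the halogens.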